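Swapping the Ring on the Thiocarbonyl Carbon

The source may report more compounds than this note shows. Statements on the series, on what has been measured and on what is new or still open speak of the compounds shown alone.

Measured compounds:
compound 1 `Cc1cccc(/C(N)=N/NC(=S)N2CCSCC2)n1`: 60.1%
compound 2 `N/C(=N\NC(=S)N1CCCCC1)c1ccccn1`: 86.5%
compound 3 `Cc1cccc(/C(N)=N/NC(=S)N2CCOCC2)n1`: 34.7%

In a functional assay on A-375 cells (Homo sapiens) for cytotoxicity, read by MTT assay, with a stated time of 72 h, tested at 3 uM (a lower number here means less inhibition of growth, a higher number more inhibition of growth at the concentration tested), compound 3 gives 34.7%, the lowest of the three numbers, with compound 1 nearest and compound 2 furthest away. Compound 4 `Cc1cccc(/C(N)=N/NC(=S)N2CCCCC2)n1` differs from compound 3 in one place: piperidin-1-yl in place of morpholin-4-yl on a thiocarbonyl carbon. Among the compounds with values here, the only measured step touching the same position is a number 25.4 percentage points lower from compound 1 to compound 3 (beyond the scatter), a modest drop beyond the scatter. Within the data shown here, compound 2, which also carries piperidin-1-yl, gives the highest number in this assay, though it differs from compound 4 in two places and no single step connects them. Compound 4 is therefore expected to climb beyond the scatter, by a number 35.3 percentage points higher from compound 3 to compound 4 (beyond the scatter). In this assay compound 4 is estimated at 70%, with a range from 50% to 90%.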

Compound 4, percent growth inhibition at one concentration: 63.2%
For compound 4 the middle estimate is 6.8 percentage points above the measured one, and the stated range covers the measured number.
By their numbers in this assay, from the lowest: compound 3; then compounds 1 and 4 (each within the scatter of the next); then compound 2.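

In this assay, piperidin-1-yl in place of morpholin-4-yl on the thiocarbonyl carbon gives a number 28.5 percentage points higher from compound 3 to compound 4 (beyond the scatter) and piperidin-1-yl in place of thiomorpholin-4-yl gives a number 3.1 percentage points higher from compound 1 to compound 4 (within the scatter), so of these three rings only morpholin-4-yl stands apart. Methyl in place of hydrogen on an aromatic carbon gives a number 23.3 percentage points lower from compound 2 to compound 4 (beyond the scatter), which shows that a change away from the thiocarbonyl carbon also moves the number.

Nothing at hand explains these steps. As far as these compounds go, whether piperazin-1-yl or an open-chain dimethylamino group on the thiocarbonyl carbon would match piperidin-1-yl remains open.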